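Moving the Chlorine on the Benzyl Group of Compound 2

This account rests on a few compounds, and the source may have more. Where it says the series, first, only, none or still open, it means among the compounds named here.

Three compounds have been measured in a functional assay on MCF7 cells (Homo sapiens) for inhibition, read by MTT assay, with a stated time of 72 h; on this read-out lower numbers stand for stronger inhibition and higher numbers for weaker inhibition:
- compound 1 `Cc1cccc(Nc2nc(SCc3cn(Cc4ccccc4Cl)nn3)nc(-c3ccccc3)c2C#N)c1` gives 19600 nM
- compound 2 `N#Cc1c(Nc2ccccc2F)nc(SCc2cn(Cc3ccccc3Cl)nn2)nc1-c1ccccc1` gives 8060 nM
- compound 3 `N#Cc1c(Nc2ccc(F)cc2)nc(SCc2cn(Cc3ccccc3Cl)nn2)nc1-c1ccccc1` gives 19900 nM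

Compound 2 stands lowest, and both steps to it lie beyond the scatter: a 2.4-fold lower number from compound 1 to compound 2 (0.39 log units; beyond the scatter) and a 2.5-fold higher number from compound 2 to compound 3 (0.39 log units; beyond the scatter), so it is the most potent of the three. The remaining step, a 1.0-fold higher number from compound 1 to compound 3 (0.01 log units; within the scatter), stays within the scatter.

Compound 4 `N#Cc1c(Nc2ccccc2F)nc(SCc2cn(Cc3ccc(Cl)cc3)nn2)nc1-c1ccccc1` differs from compound 2 by 4-chlorophenyl in place of 2-chlorophenyl on a saturated chain carbon bound to an aromatic nitrogen. Every measured step changes the aryl group on the nitrogen instead; none touches the chlorobenzyl group, so there is no measured guide for this change. With nothing pointing either way, compound 4 is expected to sit close to compound 2, a step of a 1.1-fold higher number from compound 2 to compound 4 (0.02 log units; within the scatter). The estimate for compound 4 in this assay is 8500 nM, with a range from 3500 nM to 20000 nM.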

Compound 4, half-maximal inhibitory concentration: > 64000 nM
Compound 4 ended at the assay's limit; the forecaster's own chance of this, stated with the estimate: 5%; middle value at least 7.5-fold (0.87 log units) away from the limit.
By their numbers in this assay, from the lowest: compound 2; then compounds 1 and 3 (each within the scatter of the next). At a limit, above all of these: compound 4.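

Until now, only the aryl group on the nitrogen had changed, and those steps were modest at most. The chlorobenzyl group matters more in this assay: 2-chlorobenzyl to 4-chlorobenzyl, the same atoms joined differently, gives an at least 7.9-fold higher number from compound 2 to compound 4 (0.89 log units; beyond the scatter). Compound 4 reads > 64000 nM, which is a limit of the assay and not a number.

On these data alone, it remains open whether a plain benzyl group or a bromobenzyl group would read like compound 2 or like compound 4. As far as these compounds go, the same change also remains untested with other aryl groups on the nitrogen.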